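The source may hold more compounds than are shown below. What is called first, only, known or untested is meant among the compounds shown, and "the series" means these compounds.

In a functional assay on HEK293 cells for agonist activity at Vasopressin V2 receptor (Homo sapiens), read by a luciferase reporter and cAMP accumulation (a lower number here means that less compound is needed, a higher number that more compound is needed for the effect), compound 2, `Cc1cc(C(=O)N2CCCCc3ccccc32)ccc1CNC(=O)Nc1ccccc1F`, gives 30 nM. Among the three measured compounds it holds the second highest number: compound 1, `Cc1cc(C(=O)N2CCCCc3ccccc32)ccc1CNC(=O)Nc1c(F)cccc1F`, gives 2.1 nM, while compound 3, `Cc1cc(C(=O)N2CCCCc3ccccc32)ccc1CNC(=O)N1CCC[C@@H]1C(=O)N(C)C`, gives 380 nM. Compound 4, `Cc1cc(C(=O)N2CCCCc3ccccc32)ccc1CNC(=O)N1CCC[C@H]1C(=S)N(C)C`, has not yet been measured in this assay. Its difference from compound 2 is a group of 10 heavy atoms (7 carbon, 2 nitrogen, 1 sulfur; one five-membered non-aromatic ring with 1 hetero atom) in place of a group of 8 heavy atoms (6 carbon, 1 nitrogen, 1 fluorine; one six-membered aromatic ring of carbon only), on a carbonyl carbon.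

Within the data shown here, the step that bears most directly on this change is the one from compound 2 to compound 3, in which the (2-fluorophenyl)amino group was also replaced by a pyrrolidine carrying a dimethylcarbamoyl group; that step gave a 13-fold higher number from compound 2 to compound 3 (1.10 log units; beyond the scatter). The related step from compound 1 to compound 3 gave a 180-fold higher number from compound 1 to compound 3 (2.26 log units; beyond the scatter). Among the measured compounds shown here, compound 4 carries a group of the same kind, differing from that of compound 3 only in a sulfur atom in place of oxygen and in the sense of its stereocentre, and none of the measured compounds shows the effect of either of these features on its own. Compound 4 is therefore expected to show a step of about a 12-fold higher number from compound 2 to compound 4 (1.07 log units; beyond the scatter) in this assay, a large rise in the number. The value of compound 4 is estimated at 350 nM, within a range from 100 nM to 1200 nM.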

Compound 4, half-maximal effective concentration: 3.2 nM
Estimate against measurement, compound 4: 110-fold (2.04 log units) above; the measured number lies below the stated range.
By their numbers in this assay, from the lowest: compounds 1 and 4 (each within the scatter of the next); then compound 2; then compound 3.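

Within this assay the pyrrolidine type of group on the carbonyl carbon is not tied to a high number, as compound 3 alone had suggested: the sulfur-bearing group gives a 9.4-fold lower number from compound 2 to compound 4 (0.97 log units; beyond the scatter) and so improves on the (2-fluorophenyl)amino group. Within that type of group the position proves very sensitive, since sulfur in place of oxygen, together with the opposite stereocentre, gives a 120-fold lower number from compound 3 to compound 4 (2.07 log units; beyond the scatter) and is the largest of the new steps. A group with no aromatic ring and no fluorine can also match the (2,6-difluorophenyl)amino group here, with a 1.5-fold higher number from compound 1 to compound 4 (0.18 log units; within the scatter) leaving the two compounds within the scatter of each other.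

Nothing shown gives a measured reason for these differences. The compounds shown leave open whether the sulfur atom, the stereocentre or the two together account for the gap between compound 3 and compound 4, and how a carboxylic acid or a methyl ester would fare in place of the sulfur-bearing amide on the pyrrolidine.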